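The source may hold more compounds than are shown below. What is called first, only, known or untested is meant among the compounds shown, and "the series" means these compounds.

Measured in a functional assay on HUVEC cells (Homo sapiens) for inhibition; on this read-out higher numbers stand for weaker inhibition and lower numbers for stronger inhibition:
- Compound 1 `CN(c1ccc(NC(=O)Oc2ccccc2)cc1)c1ccnc(Nc2cccc(CS(C)(=O)=O)c2)n1`: 224 nM
- Compound 2 `CN(c1ccc(N/C(S)=N/c2ccccc2)cc1)c1ccnc(Nc2cccc(CS(C)(=O)=O)c2)n1`: 6 nM
- Compound 3 `CN(c1ccc(NS(=O)(=O)Cc2ccccc2)cc1)c1ccnc(Nc2cccc(CS(C)(=O)=O)c2)n1`: 350 nM

Compound 3 sits in the high group of numbers. The measured steps show this: a 58-fold higher number from compound 2 to compound 3 (1.77 log units; beyond the scatter), beyond the scatter, while a 1.6-fold higher number from compound 1 to compound 3 (0.19 log units; within the scatter) stays within it.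

The change that leads to compound 4 `CN(c1ccc(NC(=N)Nc2ccccc2)cc1)c1ccnc(Nc2cccc(CS(C)(=O)=O)c2)n1` is a group of 9 heavy atoms (7 carbon, 2 nitrogen; one six-membered aromatic ring of carbon only) in place of a group of 10 heavy atoms (7 carbon, 2 oxygen, 1 sulfur; one six-membered aromatic ring of carbon only), on a nitrogen on an aromatic ring. Among the measured compounds shown here, two measured steps bear on it most, a 37-fold lower number from compound 1 to compound 2 (1.57 log units; beyond the scatter) and a 58-fold higher number from compound 2 to compound 3 (1.77 log units; beyond the scatter), both large. The group of compound 2, at 6 nM, also has 9 heavy atoms and one six-membered aromatic ring of carbon only, and it contains nitrogen, as the entering group does. The groups of compound 1 and compound 3 contain none. For the measured compounds named here, the two groups still differ, with sulfur in one and a second nitrogen in the other, and no measured compound carries the entering group itself. A sizeable move to a lower number is therefore expected in this assay, though probably not the whole distance. The expected size is a 10-fold lower number from compound 3 to compound 4 (1.00 log units; beyond the scatter). For compound 4 the estimated value is 35 nM, with an expected range of 6 nM to 200 nM.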

Compound 4, half-maximal inhibitory concentration: 596 nM
Compound 4: middle estimate off by 17-fold (1.23 log units), on the low side, and the stated range ends below it.
By their numbers in this assay, from the lowest: compound 2; then compounds 1, 3 and 4 (each within the scatter of the next, the first and the last beyond it).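

In this assay, the step of a 99-fold higher number from compound 2 to compound 4 (2.00 log units; beyond the scatter) shows that the nitrogen shared by these two groups does not carry the low number, since a second nitrogen in place of the sulfur is enough to lose it. Compound 4 falls in with the other two groups on this aromatic-ring nitrogen: a 1.7-fold higher number from compound 3 to compound 4 (0.23 log units; within the scatter) stays within the scatter, and a 2.7-fold higher number from compound 1 to compound 4 (0.42 log units; beyond the scatter) is only modest. Sulfur alone does not mark out the low number either, as compound 3 carries sulfur in its benzylsulfonyl group, so among these four only the group of compound 2 stands apart.

Nothing available here explains that difference. Still open, from the compounds shown here alone, is whether a urea, with oxygen in place of the sulfur of compound 2, or a thiourea bearing benzyl instead of phenyl would keep the low number.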